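Bromo for Chloro on the Fused Ring: Solubility Outlook

The source may hold more compounds than are shown below. What is called first, only, known or untested is meant among the compounds shown, and "the series" means these compounds.

Measured compounds:
- compound 1, `Cc1c(COc2cccc(OCC3CCOCC3)n2)[nH]c2ccccc2c1=O`: 3000 nM
- compound 2, `Cc1c(COc2cccc(OCC3CCOCC3)c2)[nH]c2ccc(Cl)cc2c1=O`: a limit, < 1000 nM

In a physicochemical assay for solubility, at pH 6.8 (a higher number here means a more soluble compound, a lower number a less soluble compound), compound 1 gives 3000 nM. For compound 2, this assay reports no number, only a limit of < 1000 nM. Compound 2 therefore stands at the limit of < 1000 nM in this assay, at which 1 of the 2 values shown sits, and its true solubility is not pinned down beyond that. Among the compounds with values here, because the second value is only a limit, the gap between compound 1 and compound 2 cannot be sized, and no pair of measured compounds differs in a single place, so no measured step is available here.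

Compound 3, `Cc1c(COc2cccc(OCC3CCOCC3)c2)[nH]c2ccc(Br)cc2c1=O`, has not yet been measured in this assay. It differs from compound 2 by bromo in place of chloro on an aromatic carbon. Within the data shown here, with no measured step to lean on, the change from compound 2 to compound 3 is expected to be small, a step that the limit leaves unreadable from compound 2 to compound 3 that stays within the usual scatter, with no direction of change asserted. In this assay compound 3 is therefore estimated at 700 nM, with a range from 250 nM to 1500 nM, and it is expected that the assay may again return only a limit rather than a number.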

Compound 3, solubility: < 1000 nM
Compound 3: no number, only a limit (the forecaster's own chance of this, stated with the estimate: 70%); the middle value lies beyond the limit too.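

No step can be read from compound 2 to compound 3 in this assay, because each of the two results is a limit and not a number: the limit of < 1000 nM in this assay, at which 2 of the 3 values shown sit.

The compounds shown leave open how the true solubility of compound 3 compares with that of compound 2, and so whether bromo in place of chloro on an aromatic carbon changes it at all.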